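From compound 2 to compound 3: one group exchanged

A few compounds are considered here, and "the series" means these few. Any claim that something is new, unique, unknown or untested is made for them only; others in the source may bear on it.

- compound 1 `C[C@@]1(c2cc(NC(=O)c3ccc(C#N)cn3)ccc2F)C=C(CF)OC(N)=N1`: 2.3
- compound 2 `COc1cnc(C(=O)Nc2ccc(F)c([C@]3(C)C=C(CF)OC(N)=N3)c2)cn1`: 2.7

In a physicochemical assay for lipophilicity, read by HPLC, in phosphate buffer, measured as octanol-water partition, with a stated time of 1 h, at pH 7.4 (a higher number here means a more lipophilic compound, a lower number a more polar compound), compound 2 stands higher of the two measured compounds, at 2.7. Compound 3 `COc1cc(C#N)cnc1C(=O)Nc1ccc(F)c([C@]2(C)C=C(CF)OC(N)=N2)c1` has not yet been measured. It keeps the shared core and differs only in the group on a carbonyl carbon whose other neighbour is an amide-type nitrogen: 5-cyano-3-methoxypyridin-2-yl in place of 5-methoxypyrazin-2-yl on a carbonyl carbon. In words, 5-cyano-3-methoxypyridin-2-yl comes in place of 5-methoxypyrazin-2-yl.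

Within the data shown here, only one measured step bears on this exchange, and it sits at the same place: a number 0.40 log units higher from compound 1 to compound 2 (beyond the scatter). It is a modest step, beyond the scatter, with 5-methoxypyrazin-2-yl in place of 5-cyanopyridin-2-yl. Among the measured compounds shown here, the group entering compound 3 carries both a cyano and a methoxy, and no measured compound shows how the two combine. Part of that step may therefore be undone, so a small downward move is expected, perhaps not beyond the scatter. The estimated step is a number 0.20 log units lower from compound 2 to compound 3 (within the scatter). In this assay the estimate for compound 3 is 2.5, with an expected range from 2.1 to 2.9.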

Compound 3, distribution coefficient: 1.9
For compound 3 the middle estimate is 0.60 log units above the measured one, outside the stated range (below it).
By their numbers in this assay, from the lowest: compound 3; then compound 1; then compound 2.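

In this assay, the exchange at this place on the carbonyl carbon gives a number 0.80 log units lower from compound 2 to compound 3 (beyond the scatter), which makes compound 3 the lowest of the three compounds, with every step between them printed as beyond the scatter. The closest comparison is a number 0.40 log units lower from compound 1 to compound 3 (beyond the scatter), with methoxy in place of hydrogen on an aromatic carbon, and it shows something the first pair could not: here the larger group, with a methoxy added to the nitrile-bearing ring, goes with a lower number, whereas the methoxy-bearing 5-methoxypyrazin-2-yl of compound 2 gave the highest number of the three. Nothing available explains this drop or tells what the added methoxy does at this position.

The compounds shown leave open whether this methoxy would lower the number on a ring without the nitrile, or whether the lower number appears only when the two groups are present together. They also leave open how the number would respond if an ethoxy, an amine or a chlorine took the place of the methoxy on the same aromatic carbon.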